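Working notes: from compound 3 to compound 4

This account rests on a few compounds, and the source may have more. Where it says the series, first, only, none or still open, it means among the compounds named here.

Measured so far in an ADME assay on L6 cells (Rattus norvegicus) for cytotoxicity, read by resazurin assay, with a stated time of 72 h; a lower number here means a stronger inhibitor, a higher number a weaker inhibitor:
- compound 1 `OC(c1ccc(Cl)cc1)(c1cccnc1)c1ccccc1Cl` gives 61300 nM
- compound 2 `OC(c1ccc(Cl)cc1)(c1cccnc1)c1cccc(F)c1` gives 66000 nM
- compound 3 `CC(C)Oc1cccc(C(O)(c2ccc(Cl)cc2)c2cccnc2)c1` gives 67600 nM

Compound 3 (67600 nM) stands level with compound 1 and compound 2, as all three values lie within the scatter of one another in this assay. The next structure is compound 4 `OC(c1ccc(Cl)cc1)(c1cccnc1)c1cccc(Br)c1` with bromo in place of isopropoxy on an aromatic carbon and the rest of the structure unchanged.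

Among the compounds with values here, two measured steps bear on this change. The closer one is a 1.0-fold higher number from compound 2 to compound 3 (0.01 log units; within the scatter) with isopropoxy in place of fluoro on an aromatic carbon, and it lies within the scatter. The other is a 1.1-fold higher number from compound 1 to compound 2 (0.03 log units; within the scatter) with 3-fluorophenyl in place of 2-chlorophenyl, also within the scatter. Within the data shown here, no compound with bromo has been measured yet, so the estimate leans on these flat steps alone. The expected change is a 1.1-fold lower number from compound 3 to compound 4 (0.05 log units; within the scatter) and no step beyond the scatter is expected. The estimate for compound 4 is 60000 nM with 32000 nM and 100000 nM as the expected lower and upper ends.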

Compound 4, half-maximal inhibitory concentration: 54100 nM
Compound 4: the middle estimate sits 1.1-fold (0.04 log units) above what was measured; low and high end bracket the measured number.
By their numbers in this assay, from the lowest: compounds 4, 1, 2 and 3 (each within the scatter of the next).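

In this assay, bromo in place of isopropoxy gives a 1.2-fold lower number from compound 3 to compound 4 (0.10 log units; within the scatter), and bromo in place of fluoro gives a 1.2-fold lower number from compound 2 to compound 4 (0.09 log units; within the scatter). This aromatic carbon, meta to a large group, therefore now carries fluoro, isopropoxy and bromo with every pairwise step within the scatter, even though the swap from isopropoxy to bromo takes the substituent from 4 heavy atoms to 1 and removes its only hydrogen-bond acceptor. The aryl swap gives the same picture, with 3-bromophenyl in place of 2-chlorophenyl giving a 1.1-fold lower number from compound 1 to compound 4 (0.05 log units; within the scatter), and nothing available explains why the read-out stays this flat across the four compounds.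

The compounds shown leave open whether an amine, a carboxylic acid or a longer chain on this aromatic carbon would give a step beyond the scatter, since all three groups compared here are uncharged and small to moderate in size. They also leave open whether the flat read-out extends to the parts of the shared core held constant across the set, as none of the steps here alters those parts.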